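The source may hold more compounds than are shown below. What is called first, only, known or untested is meant among the compounds shown, and "the series" means these compounds.

Compound 1 `CCCS(=O)(=O)NCCOc1nc(C2CC2)nc(NS(=O)(=O)c2ccc(C(C)C)cn2)c1Oc1ccccc1OC` gives 288 nM in a functional assay for inhibition of Endothelin-1 receptor (Rattus norvegicus); on this read-out higher numbers stand for weaker binding and lower numbers for tighter binding. Going by the values given here, compound 2 `CCS(=O)(=O)NCCOc1nc(C2CC2)nc(NS(=O)(=O)c2ccc(C(C)C)cn2)c1Oc1ccccc1OC` gives 347 nM in this assay, and the step of a 1.2-fold higher number from compound 1 to compound 2 (0.08 log units; within the scatter) shows that trimming the sulfonyl chain hardly moves the number; compound 2 stands within the scatter of compound 1, the only other value available. Compound 3 `CCCS(=O)(=O)NCCCOc1nc(C2CC2)nc(NS(=O)(=O)c2ccc(C(C)C)cn2)c1Oc1ccccc1OC` differs from compound 2 by ((propylsulfonyl)amino)methyl in place of (ethylsulfonyl)amino on a saturated chain carbon, two bonds along the chain from an oxygen on an aromatic ring. Among the compounds with values here, the sulfonyl-chain step bears on this only in part, and the added link to the ring oxygen has no measured counterpart. Compound 3 is therefore expected to show little change, a 1.2-fold lower number from compound 2 to compound 3 (0.06 log units; within the scatter), and is estimated at 300 nM, ranging from 100 nM to 900 nM.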

Compound 3, dissociation constant: 245 nM
Beside the measured number, compound 3's estimate is 1.2-fold (0.09 log units) above it; the measured number falls inside the stated range.
By their numbers in this assay, from the lowest: compounds 3, 1 and 2 (each within the scatter of the next).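

On this saturated chain carbon, two bonds along the chain from an oxygen on an aromatic ring, ((propylsulfonyl)amino)methyl in place of (propylsulfonyl)amino gives a 1.2-fold lower number from compound 1 to compound 3 (0.07 log units; within the scatter) in this assay, so this change alone leaves the number unmoved. With the sulfonyl chain changed as well, ((propylsulfonyl)amino)methyl in place of (ethylsulfonyl)amino gives a 1.4-fold lower number from compound 2 to compound 3 (0.15 log units; within the scatter), which also stays flat. No measured evidence accounts for this result. Still open, going by these compounds, is whether a longer chain at this place, or an amine or a carboxylic acid in place of the sulfonyl group, would move the number beyond the scatter.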